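Benzyl thioether in place of a cumyl group on the shared core

The source may hold more compounds than are shown below. What is called first, only, known or untested is meant among the compounds shown, and "the series" means these compounds.

Compound 1 `OC[C@H]1O[C@@H](n2cnc3c(OCc4ccccc4)ncnc32)[C@H](O)[C@@H]1O`: 2090 nM
Compound 2 `CC(C)(Sc1ncnc2c1ncn2[C@@H]1O[C@H](CO)[C@@H](O)[C@H]1O)c1ccccc1`: 21400 nM

In an assay on isolated protein for binding affinity to Equilibrative nucleoside transporter 1 (Homo sapiens) (on this read-out lower numbers stand for stronger inhibition and higher numbers for weaker inhibition), compound 2 gives 21400 nM, the higher of the two numbers recorded, while compound 1 gives 2090 nM in this assay. Compound 3 `Cc1cccc(CSc2ncnc3c2ncn3[C@@H]2O[C@H](CO)[C@@H](O)[C@H]2O)c1` differs from compound 2 by 3-methylbenzyl in place of 1-methyl-1-phenylethyl on a sulfur. Since compound 1, which carries a benzyl group on oxygen, gives 2090 nM, a move toward a benzyl-type group is expected to bring a lower number, and a step of about a 6.1-fold lower number from compound 2 to compound 3 (0.79 log units; beyond the scatter) is estimated. Compound 3 is therefore expected to give 3500 nM in this assay, with a range from 900 nM to 13000 nM.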

Compound 3, half-maximal inhibitory concentration: 12000 nM
For compound 3 the middle estimate is 3.4-fold (0.54 log units) below the measured one; the measured number falls inside the stated range.
By their numbers in this assay, from the lowest: compound 1; then compounds 3 and 2 (each within the scatter of the next).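

In this assay, 3-methylbenzyl in place of 1-methyl-1-phenylethyl on a sulfur gives a 1.8-fold lower number from compound 2 to compound 3 (0.25 log units; within the scatter), so these two groups are not told apart at this position. (3-Methylbenzyl)sulfanyl in place of benzyloxy on an aromatic carbon gives a 5.7-fold higher number from compound 1 to compound 3 (0.76 log units; beyond the scatter), so a benzyl-type group on sulfur does not match the number of compound 1. The compounds shown leave open whether a plain benzyl on the sulfur, or an amine or a carboxylic acid on its ring, would shift the number. No measurement at hand explains either step.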